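The source may hold more compounds than are shown below. What is called first, only, known or untested is meant among the compounds shown, and "the series" means these compounds.

Measured so far:
- Compound 1, `CCc1cccc(NC(=O)CN2CCC(c3cccc[n+]3[O-])CC2)c1`, in a functional assay on HEK293 cells for agonist activity at D(4) dopamine receptor (Homo sapiens), read by FLIPR (on this read-out lower numbers stand for smaller maximal responses and higher numbers for larger maximal responses), gives 62%.
- Compound 2, `Cc1cc(NC(=O)CN2CCC(c3cccc[n+]3[O-])CC2)ccc1F`, in this assay gives 75%.

Compound 1 has the lower of the two numbers; the step of a number 13 percentage points higher from compound 1 to compound 2 (beyond the scatter) is the only measured one, and it swaps the whole ring on the amide nitrogen rather than one group on it. Compound 3, `CC(C)Oc1cccc(NC(=O)CN2CCC(c3cccc[n+]3[O-])CC2)c1`, is not yet measured. It differs from compound 1 in one place: isopropoxy in place of ethyl on an aromatic carbon. Among the measured compounds shown here, no measured step exchanges ethyl for isopropoxy, so the one step gives only a loose guide, suggesting a small change at most. The expected change is a number 3 percentage points higher from compound 1 to compound 3 (within the scatter), within the scatter. For compound 3 the estimate is 65%, ranging from 48% to 82%.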

Compound 3, largest response reached (reported as efficacy), in percent of the reference or control that the assay uses: 48%
Estimate against measurement, compound 3: 17 percentage points above, and the stated range covers the measured number.
By their numbers in this assay, from the lowest: compound 3; then compound 1; then compound 2.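

Replacing ethyl with isopropoxy on this aromatic carbon, meta to a large group, changes only one substituent, and in this assay it gives a number 14 percentage points lower from compound 1 to compound 3 (beyond the scatter). The maximal response is therefore sensitive to this single position, not only to exchange of the whole ring on the amide nitrogen, and this change lowers the number. Nothing available explains the drop.

The compounds shown do not separate the role of the oxygen from that of the branched carbons of isopropoxy. Methoxy or isopropyl at the same position would test those two parts separately.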